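A Bromo Substituent Added to Compound 2

The source may report more compounds than this note shows. Statements on the series, on what has been measured and on what is new or still open speak of the compounds shown alone.

Compound 1 `COc1ccc(/C(Cl)=C/C=C(\C#N)C(=O)c2c[nH]c3ccccc23)cc1`: 76.9%
Compound 2 `COc1cc(/C(Cl)=C/C=C(\C#N)C(=O)c2c[nH]c3ccccc23)cc(OC)c1OC`: 73.3%
Compound 3 `Cc1[nH]c2ccccc2c1C(=O)/C(C#N)=C/C=C(\Cl)c1ccc(Br)cc1`: 78.3%

These three compounds were tested in a functional assay for inhibition, read by Griess assay, with a stated time of 150 min, tested at 1 mM; on this read-out lower numbers stand for less inhibition and higher numbers for more inhibition at the one concentration tested (going by the name of the read-out). On those numbers compound 2 sits at the low end of the three, yet its gaps to compound 1 and compound 3 are both within the usual scatter, so the three cannot be told apart. Compound 4 `COc1cc(/C(Cl)=C/C=C(\C#N)C(=O)c2c[nH]c3ccc(Br)cc23)cc(OC)c1OC` has not been measured yet. It differs from compound 2 in one place: bromo in place of hydrogen on an aromatic carbon. Among the compounds with values here, no change between two measured compounds is recorded, so there is no measured step to lean on. The three measured numbers simply lie close together. The step in this assay is therefore expected to be a number 0.7 percentage points higher from compound 2 to compound 4 (within the scatter), none beyond the scatter. Compound 4 is expected to give about 74%, between 60% and 86%.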

Compound 4, a percentage reported as inhibition, at one concentration (the size of the read-out at that concentration, not a potency): 36.7%
Estimate against measurement, compound 4: 37.3 percentage points above; measured number outside the range, below it.
By their numbers in this assay, from the lowest: compound 4; then compounds 2, 1 and 3 (each within the scatter of the next).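

In this assay, the change from 1H-indol-3-yl to 5-bromo-1H-indol-3-yl gives a number 36.6 percentage points lower from compound 2 to compound 4 (beyond the scatter), so a single added bromo on this aromatic carbon can strongly alter the read-out. The earlier compounds shown here, all within the scatter of one another and differing in more than one place, gave no sign of this sensitivity. Nothing available here accounts for the drop.

Going by these compounds, whether fluoro or an amine on this same carbon would give a similar drop stays open. So does whether bromo here would do the same on the core of compound 1.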